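The source may report more compounds than this note shows. Statements on the series, on what has been measured and on what is new or still open speak of the compounds shown alone.

Compound 2, `COc1ccc(F)cc1[C@H]1COCC2(C1)OCCN[C@H]2c1ccc(F)cc1`, gives 10 nM in an assay on CHO cells for displacement of a labelled ligand from Substance-P receptor (Homo sapiens) (a higher number here means a weaker inhibitor, a lower number a stronger inhibitor), the lowest of the two numbers recorded. Among the compounds with values here, the only comparison is compound 1, `c1ccc(C2CCC3(OCCNC3c3ccccc3)OC2)cc1`, which in this assay gives 170 nM, a gap beyond the scatter. Compound 3, `COc1ccc(OC)c([C@H]2COCC3(C2)OCCN[C@H]3c2ccc(F)cc2)c1`, differs from compound 2 by methoxy in place of fluoro on an aromatic carbon. Within the data shown here, no measured pair shows this change, so its size is unknown from the data. The step of a 1.6-fold higher number from compound 2 to compound 3 (0.20 log units; within the scatter) is expected to be small, at most a modest weakening hardly beyond the scatter. For compound 3 the estimate in this assay is 16 nM, with a range from 5 nM to 50 nM.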

Compound 3, half-maximal inhibitory concentration: 16 nM
Compound 3: middle estimate and measured number agree at the digits printed, within the range that was stated.
By their numbers in this assay, from the lowest: compounds 2 and 3 (each within the scatter of the next); then compound 1.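

At the aromatic carbon meta to a large group and para to a methoxy group, methoxy in place of fluoro gives a 1.6-fold higher number from compound 2 to compound 3 (0.20 log units; within the scatter) in this assay. Within the data shown here, this position therefore takes either group without a change beyond the scatter, although methoxy brings one more heavy atom and a hydrogen-bond acceptor, which the earlier compounds could not show. Nothing measured here accounts for this outcome. From the compounds shown here alone, whether an amine, a carboxylic acid or a longer chain on this carbon would also stay within the scatter remains open.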